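The source may report more compounds than this note shows. Statements on the series, on what has been measured and on what is new or still open speak of the compounds shown alone.

In a functional assay on Bel7402/5-FU cells (Homo sapiens) for antiproliferative activity, read by MTT assay, with a stated time of 72 h (a lower number here means a stronger inhibitor, a higher number a weaker inhibitor), compound 1 `C=C1C(=O)O[C@H]2[C@H]1CC/C(Cn1cc(Cn3cc(F)c(=O)n(Cc4ccccc4)c3=O)nn1)=C\CC[C@@]1(C)O[C@@H]21` gives 8840 nM, compound 2 `C=C1C(=O)O[C@H]2[C@H]1CC/C(Cn1cc(Cn3cc(F)c(=O)n(Cc4ccc(F)cc4)c3=O)nn1)=C\CC[C@@]1(C)O[C@@H]21` gives 4860 nM, and compound 3 `C=C1C(=O)O[C@H]2[C@H]1CC/C(COC(=O)Cn1cc(F)c(=O)n(Cc3ccc(Cl)cc3)c1=O)=C\CC[C@@]1(C)O[C@@H]21` gives 2420 nM. Compound 3 stands at the low end of these three numbers, yet compound 2 lies within the scatter of it, and only compound 1 stands beyond it. Compound 4 `C=C1C(=O)O[C@H]2[C@H]1CC/C(COC(=O)Cn1cc(F)c(=O)n(Cc3cc(F)ccc3F)c1=O)=C\CC[C@@]1(C)O[C@@H]21` differs from compound 3 by 2,5-difluorophenyl in place of 4-chlorophenyl on a saturated chain carbon bound to an aromatic nitrogen. For the measured compounds named here, the one measured step that resembles this, a 1.8-fold lower number from compound 1 to compound 2 (0.26 log units; within the scatter), also altered a halogen on the benzyl group and stayed within the scatter, so no step beyond the scatter is expected in this assay. Compound 4 is therefore estimated at 2600 nM, between 1200 nM and 5600 nM, an expected step of a 1.1-fold higher number from compound 3 to compound 4 (0.03 log units; within the scatter) that should remain within the scatter.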

Compound 4, half-maximal inhibitory concentration: 4610 nM
For compound 4 the middle estimate is 1.8-fold (0.25 log units) below the measured one; measured number inside the range.
By their numbers in this assay, from the lowest: compounds 3, 4, 2 and 1 (each within the scatter of the next, the first and the last beyond it).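

Swapping 4-chlorophenyl for 2,5-difluorophenyl gives a 1.9-fold higher number from compound 3 to compound 4 (0.28 log units; within the scatter) in this assay. The earlier step at this benzyl group only put fluoro in place of hydrogen, on compounds with a different link to the shared core, whereas this one shows that the chlorine can be exchanged for two fluorines on this link without a step beyond the scatter. Nothing available here accounts for this result. Still open, as far as these compounds go, is whether an amine or a carboxylic acid on this ring, or a longer chain in place of the benzyl carbon, would move the number beyond the scatter.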